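A Double Bond in the Saturated Ring of Compound 1

The source may report more compounds than this note shows. Statements on the series, on what has been measured and on what is new or still open speak of the compounds shown alone.

Compound 1 `COc1ccccc1-n1nc(C2CC(C)(C)OC(C)(C)C2)cc1-c1ccc(Cl)cc1` was tested in an assay on HEK293 cells for inhibition of Voltage-dependent N-type calcium channel subunit alpha-1B (Homo sapiens), read by fluorescence and calcium flux, with a stated time of 5 min (on this read-out lower numbers stand for stronger inhibition and higher numbers for weaker inhibition), where compound 1 gives 1 nM. Among the three compounds measured so far, compound 1 stands lowest, which here means it is the most potent. Compound 2 `COc1ccccc1-n1nc(C2CC(C)(C)OC(C)(C)C2)cc1-c1ccc(C)nc1` gives 6 nM in this assay, and compound 3 `CC1(C)CC(c2cc(-c3ccc(Cl)cc3)n(-c3ccccn3)n2)CC(C)(C)O1` gives 12 nM. The step of a 6.0-fold higher number from compound 1 to compound 2 (0.78 log units; beyond the scatter) swaps the aryl group on one carbon of the core for a pyridine, while the step of a 12-fold higher number from compound 1 to compound 3 (1.08 log units; beyond the scatter) swaps the aryl group on the ring nitrogen for a pyridine; both losses lie beyond the scatter.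

Compound 4 `COc1ccccc1-n1nc(C2=CC(C)(C)OC(C)(C)C2)cc1-c1ccc(Cl)cc1` differs from compound 1 in a third place: a group of 10 heavy atoms (9 carbon, 1 oxygen; one six-membered non-aromatic ring with 1 hetero atom) in place of a group of 10 heavy atoms (9 carbon, 1 oxygen; one six-membered non-aromatic ring with 1 hetero atom), on an aromatic carbon. The saturated ring becomes unsaturated while keeping the same atom count and the same single acceptor. Among the compounds with values here, neither measured step touches this ring, so the two steps give no direct guidance on its effect; they show only that changes elsewhere on the core cost potency. With the aromatic groups of compound 1 left untouched, the estimated step from compound 1 to compound 4 is expected to be small, a 1.5-fold higher number from compound 1 to compound 4 (0.18 log units; within the scatter), with no clear direction beyond the scatter. Compound 4 is therefore expected to give about 1.5 nM in this assay, in a range from 0.5 nM to 5 nM.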

Compound 4, half-maximal inhibitory concentration: 3 nM
Beside the measured number, compound 4's estimate is 2.0-fold (0.30 log units) below it, within the range that was stated.
By their numbers in this assay, from the lowest: compound 1; then compounds 4, 2 and 3 (each within the scatter of the next, the first and the last beyond it).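

Adding one double bond to the 2,2,6,6-tetramethyloxan-4-yl ring, with the counts of heavy atoms and hydrogen-bond acceptors unchanged, gives in this assay a clear loss of potency (a 3.0-fold higher number from compound 1 to compound 4 (0.48 log units; beyond the scatter)). Within the data shown here, the earlier steps changed only the aromatic groups, so this is the first sign that the non-aromatic ring on the aromatic carbon also matters, and that keeping those counts the same is not enough to hold the number of compound 1. Nothing shown here explains why the double bond has this effect.

From the compounds shown here alone, it remains open how much more this ring can be altered, for example by putting an amine nitrogen in place of the ring oxygen, removing the four methyl groups, or replacing the ring with a simple open chain such as tert-butyl. Going by these compounds, it is also open whether the same double bond would cost a similar amount when paired with the 6-methylpyridin-3-yl group of compound 2 or the pyridin-2-yl group of compound 3.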